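Chloro to nitrooxy: one small change, one open number

A few compounds are considered here, and "the series" means these few. Any claim that something is new, unique, unknown or untested is made for them only; others in the source may bear on it.

In a functional assay on SW480 cells (Homo sapiens) for antiproliferative activity, read by CCK-8 assay and cell counting, with a stated time of 72 h (a lower number here means a stronger inhibitor, a higher number a weaker inhibitor), compound 3 (`O=C(Nc1ccccc1)c1ccc(CCl)cc1`) gives 900 nM as the lowest of three numbers, clearly apart from the other two. Compound 4 (`O=C(Nc1ccccc1)c1ccc(CO[N+](=O)[O-])cc1`) differs from compound 3 in one place, with nitrooxy in place of chloro on a saturated chain carbon bound to an aromatic carbon. No single change of this kind has been measured. The only hint comes from two larger molecules: compound 2 (`O=C(Nc1ccccc1OC(=O)c1ccc(CO[N+](=O)[O-])cc1)c1ccc(CO[N+](=O)[O-])cc1`) at 3800 nM carries nitrooxy where compound 1 (`O=C(Nc1ccccc1OC(=O)c1ccc(CCl)cc1)c1ccc(CCl)cc1`) at 6900 nM carries chloro, and these values lie within the scatter of each other. So no step beyond the scatter is expected in this assay here, with an estimated 1.1-fold lower number from compound 3 to compound 4 (0.05 log units; within the scatter) inside that scatter. The estimate for compound 4 is 800 nM within an expected range of 300 nM to 2400 nM in this measurement.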

Compound 4, half-maximal inhibitory concentration: 800 nM
Compound 4: the middle estimate sits on the measured number at the digits printed; the measured number falls inside the stated range.
By their numbers in this assay, from the lowest: compounds 4 and 3 (each within the scatter of the next); then compounds 2 and 1 (each within the scatter of the next).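

A direct one-place reading of chloro to nitrooxy on a saturated chain carbon bound to an aromatic carbon now exists: in this assay, the swap gives a 1.1-fold lower number from compound 3 to compound 4 (0.05 log units; within the scatter) on the shared core. Nitrooxy brings four heavy atoms where chloro had one, yet the two compounds cannot be told apart by their numbers. Nothing on hand explains why the two groups read alike.

The compounds shown leave open whether an amine or a carboxylic acid at this place would shift the number beyond the scatter. On these data alone, whether the same swap reads alike on a longer chain also remains open.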